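Ethyl to methyl at the edge of the assay

A few compounds are considered here, and "the series" means these few. Any claim that something is new, unique, unknown or untested is made for them only; others in the source may bear on it.

In a functional assay on DU-145 cells (Homo sapiens) for inhibition, read by MTT assay, with a stated time of 48 h (on this read-out lower numbers stand for stronger inhibition and higher numbers for weaker inhibition), compound 1 `Cn1c(/C=C2\SC(=O)N(CC(=O)Nc3cc(C(C)(C)C)on3)C2=O)nc2ccccc21` gives 31400 nM and compound 2 `Cn1c(/C=C2\SC(=O)N(CC(=O)N3CCOCC3)C2=O)nc2ccccc21` gives 41100 nM as measured numbers. Compound 3 `CCn1c(/C=C2\SC(=O)N(CC(=O)N3CC(C)OC(C)C3)C2=O)nc2ccccc21` reads > 50000 nM which is a limit of the assay and not a number. Compound 4 `CC1CN(C(=O)CN2C(=O)S/C(=C\c3nc4ccccc4n3C)C2=O)CC(C)O1` differs from it by hydrogen in place of methyl on a saturated chain carbon bound to an aromatic nitrogen that is, hydrogen in place of methyl on a saturated chain carbon bound to an aromatic nitrogen, or ethyl to methyl. Among the measured compounds shown here, the only measured step of a 1.3-fold higher number from compound 1 to compound 2 (0.12 log units; within the scatter) concerns a group on a carbonyl carbon and lies within the scatter, so no measured step tests this change. The step expected in this assay is a number no higher from compound 3 to compound 4 (the limit leaves the size open) and is estimated to stay within the scatter. Compound 4 is expected at 50000 nM with an estimated range from 28000 nM to 90000 nM and may report only a limit.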

Compound 4, half-maximal inhibitory concentration: > 50000 nM
Compound 4: only a limit was reported; the forecaster's own chance of this, stated with the estimate: 45%; the middle value sits exactly at the limit.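

Going from ethyl to methyl on a saturated chain carbon bound to an aromatic nitrogen does not bring the compound off the limit, so the step from compound 3 to compound 4 cannot be read: the limit of > 50000 nM in this assay, at which 2 of the 4 values shown sit.

On a carbonyl carbon, 2,6-dimethylmorpholin-4-yl gives an at least 1.2-fold higher number from compound 2 to compound 4 (0.08 log units; that floor lies within the scatter) and an at least 1.5-fold higher number from compound 1 to compound 4 (0.20 log units; that floor lies within the scatter), and neither floor goes beyond the scatter.

From the compounds shown here alone, whether this change has any effect in this assay stays open. A longer chain such as propyl at this place could answer that only if it gave a measured number.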